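From 1-phenylethyl to 4-fluorobenzyl on the shared core

The source may report more compounds than this note shows. Statements on the series, on what has been measured and on what is new or still open speak of the compounds shown alone.

Of the compounds shown here, three sharing one core have been tested in a functional assay on HCT-116 cells (Homo sapiens) for cytotoxicity, read by MTT assay, with a stated time of 72 h; a higher number here means a weaker inhibitor, a lower number a stronger inhibitor: compound 1 `Nc1cccc(Nc2c(C(=O)NCc3ccc(F)cc3)nc(Br)c3cccnc23)c1`, compound 2 `C[C@@H](Nc1c(C(=O)NCc2ccc(F)cc2)nc(Br)c2cccnc12)c1ccccc1` and compound 3 `CC(C)(C)OC(=O)N1CCN(c2c(C(=O)NCc3ccc(F)cc3)nc(Br)c3cccnc23)CC1`. Compound 1 gives only a limit, > 10000 nM. Compound 2 likewise gives only a limit, > 20000 nM. Compound 3 also gives only a limit, > 10000 nM. Compound 2 therefore has no number to stand on, and neither of the two others offers one for comparison.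

Compound 4 `O=C(NCc1ccc(F)cc1)c1nc(Br)c2cccnc2c1NCc1ccc(F)cc1` keeps the shared core and carries 4-fluorobenzyl in place of 1-phenylethyl on a nitrogen on an aromatic ring. Within the data shown here, the only measured step that bears on this position is a step that the two limits leave unreadable from compound 1 to compound 2, with 1-phenylethyl in place of 3-aminophenyl, and it gives no size to carry over. With no readable step to draw on, no change beyond the scatter is expected in this assay, and no direction can be argued. Compound 4 is expected to stay weak, as compound 2 gives the limit > 20000 nM. Among the measured compounds shown here, the estimated change is a number no higher from compound 2 to compound 4 (the limit leaves the size open), which is to be read as no real step. For compound 4 the expected half-maximal inhibitory concentration is 20000 nM, with an estimated range of 8000 nM to 40000 nM.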

Compound 4, half-maximal inhibitory concentration: > 20000 nM
Compound 4 ended at the assay's limit; the forecaster's own chance of this, stated with the estimate: 80%; the middle value lies on the limit itself.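

In this assay compound 4 gives only a limit, > 20000 nM. Among these compounds, compound 1 and compound 2 also give only limits, so no step to compound 4 can be read. The compounds shown leave open whether any of 3-aminophenyl, 1-phenylethyl or 4-fluorobenzyl on this nitrogen differs from the others in this assay, and by how much.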